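Moving the nitro group alone: a thiourea analogue awaits testing

A few compounds are considered here, and "the series" means these few. Any claim that something is new, unique, unknown or untested is made for them only; others in the source may bear on it.

Measured compounds:
compound 1 `CCOC(=O)C1=C(C)NC(=S)NC1c1cn(C(=O)CNc2ccc([N+](=O)[O-])c(Cl)c2)c2ccccc12` gives 29 ug/mL
compound 2 `CCOC(=O)C1=C(C)NC(=O)NC1c1cn(C(=O)CNc2ccc([N+](=O)[O-])cc2Cl)c2ccccc12` gives 5 ug/mL
compound 3 `CCOC(=O)C1=C(C)NC(=O)NC1c1cn(C(=O)CNc2ccccc2[N+](=O)[O-])c2ccccc12` gives 250 ug/mL

In a functional assay on HCT-116 cells (Homo sapiens) for cytotoxicity, read by MTT assay, with a stated time of 72 h (a lower number here means a stronger inhibitor, a higher number a weaker inhibitor), compound 1 stands second highest of the three numbers. Its nearest neighbour is compound 2, which in this assay gives 5 ug/mL, a lower number beyond the scatter; furthest away is compound 3, which in this assay gives 250 ug/mL, a higher number beyond the scatter.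

The unmeasured compound 4 `CCOC(=O)C1=C(C)NC(=S)NC1c1cn(C(=O)CNc2ccccc2[N+](=O)[O-])c2ccccc12` differs from compound 1 in one place: 2-nitrophenyl in place of 3-chloro-4-nitrophenyl on an amine nitrogen. Among the compounds with values here, the only measured step that bears on this is the one in the urea series, a 50-fold higher number from compound 2 to compound 3 (1.70 log units; beyond the scatter), where the same entering group replaced a chlorinated nitrophenyl on the same amine nitrogen. That step was large and in the direction of a weaker inhibitor. Within the data shown here, the leaving group in that step was not the same as the one leaving compound 1, so the match is not exact, but the direction it points is clear.

Compound 4 is therefore expected to show a substantially higher number than compound 1, a step of about a 10-fold higher number from compound 1 to compound 4 (1.01 log units; beyond the scatter) in this assay. The estimate for compound 4 is 300 ug/mL, with a range from 60 ug/mL to 1000 ug/mL.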

Compound 4, half-maximal inhibitory concentration: > 1000 ug/mL
Compound 4: no number, only a limit; the forecaster's own chance of this, stated with the estimate: 20%; at least 3.3-fold (0.52 log units) between middle value and limit.
By their numbers in this assay, from the lowest: compound 2; then compound 1; then compound 3. At a limit, above all of these: compound 4.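

The change from 3-chloro-4-nitrophenyl to 2-nitrophenyl on the amine nitrogen weakens compounds in the thiourea pair as well, with an at least 34-fold higher number from compound 1 to compound 4 (1.53 log units; beyond the scatter) in this assay, so the large loss seen in the urea pair, a 50-fold higher number from compound 2 to compound 3 (1.70 log units; beyond the scatter), is not confined to that series. Compound 4 has no number, only a limit: the limit of > 1000 ug/mL in this assay, at which 1 of the 4 values shown sits. The thiourea step is therefore a minimum, and its true size cannot be set against the urea step, although both run in the same direction and both lie beyond the scatter.

What the compounds shown leave open is which part of the change carries the loss, since in both pairs the chlorine leaves and the nitro group moves together, and the leaving groups of the two pairs are not the same. A plain phenyl, a phenyl carrying chlorine alone, or an amine in place of the nitro group on the same amine nitrogen would be needed to tell these contributions apart and to show how much of the activity of compound 1 depends on each.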